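Thiourea series: furan-2-ylmethyl in place of ethyl

The compounds below may be only part of what the source reports. "The series", "measured", "known", "first", "only" and "open" are said of these compounds alone.

Compound 1 `CCNC(=S)Nc1cccc(C(F)(F)F)c1` carries the ethyl thiourea on the shared core. In an ADME assay on MDBK cells (Bos taurus) for cytotoxicity, read by MTT assay, with a stated time of 96 h (a lower number here means that less compound is tolerated, a higher number that more compound is tolerated), compound 1 gives only a limit, > 100000 nM, so no number is known for it; compound 1 stands at the limit of > 100000 nM in this assay, at which 1 of the 2 values shown sits. Compound 2 `O=C(NC(=S)Nc1cccc(C(F)(F)F)c1)[C@H]1C[C@@H]2CC[C@H]1C2` is the other measured member of the set; in this assay compound 2 gives 10000 nM. Among the compounds with values here, no step between measured compounds that differ in one place is available, and the two values shown say only that compound 2 has a number where compound 1 has a limit.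

Compound 3 `FC(F)(F)c1cccc(NC(=S)NCc2ccco2)c1` differs from compound 1 by furan-2-yl in place of methyl on a saturated chain carbon bound to an amide-type nitrogen. The step from compound 1 to compound 3 in this assay is expected to be small, not clearly beyond the usual scatter, and is estimated as an at least 1.2-fold lower number from compound 1 to compound 3 (0.09 log units; that floor lies within the scatter). Compound 3 is therefore estimated at 80000 nM, with a range from 30000 nM to 200000 nM, and with a fair chance that only a limit is again reported.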

Compound 3, half-maximal cytotoxic concentration: > 100000 nM
Compound 3 ended at the assay's limit (the forecaster's own chance of this, stated with the estimate: 55%); at least 1.2-fold (0.09 log units) between middle value and limit.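

Compound 3, like compound 1, gives only a limit in this assay, so no step between the two can be read: the limit of > 100000 nM in this assay, at which 2 of the 3 values shown sit.

The compounds shown leave open whether furan-2-yl in place of methyl on a saturated chain carbon bound to an amide-type nitrogen changes the tolerated concentration at all.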